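From 1-methylbutoxy to methyl: a small expected step

The compounds below may be only part of what the source reports. "The series", "measured", "known", "first", "only" and "open" are said of these compounds alone.

Measured so far in a functional assay on B16-F10 cells (Mus musculus) for antiproliferative activity, read by MTT assay, with a stated time of 48 h; a higher number here means a weaker inhibitor, a lower number a stronger inhibitor
Compound 1 `COc1ccc(/C=C/c2cc(OC)cc(OC)c2/C=C/C(=O)c2cccc(OC)c2)cc1` gives 4.3 ug/mL
Compound 2 `CCCC(C)Oc1ccc(C(=O)/C=C/c2c(/C=C/c3ccc(OC)cc3)cc(OC)cc2OC)cc1` gives 6.7 ug/mL

Among the measured compounds shown here, compound 2 lies within the scatter of its only measured neighbour, compound 1. Compound 3 `COc1ccc(/C=C/c2cc(OC)cc(OC)c2/C=C/C(=O)c2ccc(C)cc2)cc1` differs from compound 2 by methyl in place of 1-methylbutoxy on an aromatic carbon, with methyl in place of 1-methylbutoxy on an aromatic carbon. For the measured compounds named here, one measured step bears on this change, a 1.6-fold higher number from compound 1 to compound 2 (0.19 log units; within the scatter), which brought in the 4-(1-methylbutoxy)phenyl group. Going by the values given here, with only that small step as a guide, the expected step in this assay is a 1.3-fold lower number from compound 2 to compound 3 (0.11 log units; within the scatter), none beyond the scatter. Compound 3 is expected near 5.2 ug/mL, with an estimated range from 2.6 ug/mL to 10.5 ug/mL in this assay.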

Compound 3, half-maximal inhibitory concentration: 5.3 ug/mL
Compound 3: the middle estimate sits 1.0-fold (0.01 log units) below what was measured; the range from low to high includes it.
By their numbers in this assay, from the lowest: compounds 1, 3 and 2 (each within the scatter of the next).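

Replacing 1-methylbutoxy with methyl on this aromatic carbon, para to a large group, gives a 1.3-fold lower number from compound 2 to compound 3 (0.10 log units; within the scatter) in this assay, so a much smaller group here leaves the number within the scatter. The step of a 1.2-fold higher number from compound 1 to compound 3 (0.09 log units; within the scatter), with 4-methylphenyl in place of 3-methoxyphenyl, also stays within the scatter, so none of the three aryl ketone groups can yet be told apart. No measurement here explains this result. From the compounds shown here alone, it remains open whether an amine or a carboxylic acid on this carbon would move the number beyond the scatter.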